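Chain variation on a cyclobutyl-bearing EP3 agonist scaffold

A few compounds are considered here, and "the series" means these few. Any claim that something is new, unique, unknown or untested is made for them only; others in the source may bear on it.

Measured compounds:
compound 1, `CC(C)(C)CCC1([C@H](O)/C=C/[C@H]2COC(=O)N2CCSc2nc(C(=O)O)cs2)CCC1`, 6.7 nM
compound 2, `COCCCC1([C@H](O)/C=C/[C@H]2COC(=O)N2CCSc2nc(C(=O)O)cs2)CCC1`, 25 nM
compound 3, `O=C(O)c1csc(SCCN2C(=O)OC[C@@H]2/C=C/[C@@H](O)C2(CCCCF)CCC2)n1`, 10 nM

The three compounds share one core and differ only in the chain attached to the saturated ring carbon. In an assay on isolated protein for agonist activity at prostaglandin E2 receptor EP3 subtype (Homo sapiens) (on this read-out higher numbers stand for an effect only at larger amounts of compound and lower numbers for an effect already at smaller amounts), compound 1 gives the lowest of the three numbers. Its nearest neighbour is compound 3, and that step, a 1.5-fold higher number from compound 1 to compound 3 (0.17 log units; within the scatter), lies within the scatter, so the two cannot be ordered. Compound 2 stands furthest away: a 3.7-fold higher number from compound 1 to compound 2 (0.57 log units; beyond the scatter). Between the other two, a 2.5-fold lower number from compound 2 to compound 3 (0.40 log units; beyond the scatter).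

The unmeasured compound 4, `CC#CCC1([C@H](O)/C=C/[C@H]2COC(=O)N2CCSc2nc(C(=O)O)cs2)CCC1`, is reached from compound 1 by the change (prop-1-yn-1-yl in place of neopentyl on a saturated chain carbon bound to a saturated ring carbon). The two measured steps from compound 1 bear on this: one chain variation cost a modest amount, a 3.7-fold higher number from compound 1 to compound 2 (0.57 log units; beyond the scatter), while another was neutral, a 1.5-fold higher number from compound 1 to compound 3 (0.17 log units; within the scatter). The change to compound 4 removes more of the chain than either, so a modest step toward higher numbers in this assay is expected, roughly of the size seen from compound 1 to compound 2, but a neutral outcome remains possible. Compound 4 is therefore estimated at 15 nM, within a range of 6 nM to 40 nM, which means an expected step of a 2.2-fold higher number from compound 1 to compound 4 (0.35 log units; beyond the scatter).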

Compound 4, half-maximal effective concentration: 18 nM
Beside the measured number, compound 4's estimate is 1.2-fold (0.08 log units) below it; the measured number falls inside the stated range.
By their numbers in this assay, from the lowest: compounds 1, 3, 4 and 2 (each within the scatter of the next, the first and the last beyond it).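

In this assay, prop-1-yn-1-yl in place of neopentyl on a saturated chain carbon bound to a saturated ring carbon gives a 2.7-fold higher number from compound 1 to compound 4 (0.43 log units; beyond the scatter) and so shows that a step beyond the scatter from compound 1 is not confined to the chain carrying an oxygen: it also appears with a chain of carbon alone, while compound 3 goes against any broader rule, with a 1.5-fold higher number from compound 1 to compound 3 (0.17 log units; within the scatter) as its step. Compound 4 cannot be ordered against either chain bearing a heteroatom, with a 1.8-fold higher number from compound 3 to compound 4 (0.26 log units; within the scatter) and a 1.4-fold lower number from compound 2 to compound 4 (0.14 log units; within the scatter) both inside the scatter, even though compound 2 and compound 3 are themselves separated by a 2.5-fold lower number from compound 2 to compound 3 (0.40 log units; beyond the scatter) and compound 4 therefore sits unresolved in the range they span. No measurement shown here gives a reason for any of these steps.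

The compounds shown leave open whether the step to compound 4 goes with the triple bond or with the shorter chain, a question that a plain butyl chain at this place would bear on. They also leave open how an amine or a hydroxyl at the end of the chain would read in this assay against the chains compared here.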